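Swapping the nitrogen-bound aryl ring of an amide

The source may hold more compounds than are shown below. What is called first, only, known or untested is meant among the compounds shown, and "the series" means these compounds.

Measured compounds:
compound 1 `CCN(Cc1cccs1)C(=O)c1cc2cc(C)ccc2o1`: 120 nM
compound 2 `CCN(Cc1cc[nH]c1)C(=O)COc1ccc(C)cc1`: 21800 nM
compound 3 `Cc1ccc(OCC(=O)N(Cc2cccs2)c2ccccn2)cc1`: 200 nM

The three measured compounds were tested in an assay on HEK293 cells for agonist activity at transient receptor potential cation channel subfamily M member 8 (Homo sapiens), read by fluorescence and calcium flux, with a stated time of 15 min; a lower number here means that less compound is needed, a higher number that more compound is needed for the effect. In this assay compound 1 gives 120 nM, compound 2 gives 21800 nM, and compound 3 gives 200 nM. Compound 3 therefore stands second highest of the three numbers. Its gap to compound 1 lies within the usual scatter of repeated measurements, so the two cannot be told apart on these numbers alone. Its gap to compound 2 lies well beyond that scatter, with compound 2 needing far more material for the same effect.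

Compound 4 `Cc1ccc(OCC(=O)N(Cc2cccs2)c2nccn2C)cc1` has not yet been measured in this assay. It differs from compound 3 in one place: 1-methyl-1H-imidazol-2-yl in place of pyridin-2-yl on an amide-type nitrogen. Among the measured compounds shown here, no measured pair shows the effect of exactly this exchange, so there is no step on record to lean on. The change keeps the size of the group the same while replacing one aromatic ring with another, which in similar series often leaves the number in the same region or shifts it only modestly.

On that basis compound 4 is expected to give 400 nM in this assay, with a plausible range from 100 nM to 2000 nM. The expected step is a 2.0-fold higher number from compound 3 to compound 4 (0.30 log units; within the scatter), a small loss that may well fall within the scatter.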

Compound 4, half-maximal effective concentration: 1790 nM
Beside the measured number, compound 4's estimate is 4.5-fold (0.65 log units) below it; the range from low to high includes it.
By their numbers in this assay, from the lowest: compounds 1 and 3 (each within the scatter of the next); then compound 4; then compound 2.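

In this assay, among the compounds shown here, this is the first exchange on record at the amide-type nitrogen, and putting 1-methyl-1H-imidazol-2-yl in place of pyridin-2-yl gives a 9.0-fold higher number from compound 3 to compound 4 (0.95 log units; beyond the scatter). Matching heavy-atom counts therefore do not make these two groups interchangeable here: the group's identity matters at this position, even though both are single aromatic rings with 6 heavy atoms. The groups still differ in several ways at once, since a six-membered aromatic ring with 1 hetero atom and 1 hydrogen-bond acceptor gives way to a five-membered aromatic ring with 2 hetero atoms and 2 hydrogen-bond acceptors, and no measurement available here explains the change in the number.

For the compounds shown here, with only this one pair, it remains open whether the higher number follows from the ring size, the second ring nitrogen or the methyl group. Placing a phenyl ring, an imidazol-2-yl ring without the methyl group or a 1-methyl-1H-pyrazol-5-yl ring on this nitrogen would help separate those features and show whether other rings can match compound 3.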